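Series notes: methoxycarbonyl replaces trifluoromethyl on the aminopyridine

The source may report more compounds than this note shows. Statements on the series, on what has been measured and on what is new or still open speak of the compounds shown alone.

Of the compounds shown here, three on a shared core have been measured in an assay on Ltk cells with metabotropic glutamate receptor 5 (Homo sapiens) as the target, read by fluorescence and calcium flux; on this read-out lower numbers stand for stronger inhibition and higher numbers for weaker inhibition. Compound 1 `CCOc1cccnc1Nc1cccc(C)n1` gives 40 nM in this assay. Compound 2 `CCOc1cccnc1Nc1ccccn1` gives 138 nM and compound 3 `CCOc1cccnc1Nc1cccc(C(F)(F)F)n1` gives 1900 nM. Compound 3 is the weakest of the three measured, with a 48-fold higher number from compound 1 to compound 3 (1.68 log units; beyond the scatter) and a 14-fold higher number from compound 2 to compound 3 (1.14 log units; beyond the scatter), both beyond the scatter; the smaller step is a 3.5-fold higher number from compound 1 to compound 2 (0.54 log units; beyond the scatter).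

Compound 4 `CCOc1cccnc1Nc1cccc(C(=O)OC)n1` is not yet measured. The change from compound 3 is methoxycarbonyl in place of trifluoromethyl on an aromatic carbon. Among the measured compounds shown here, no measured step covers this exchange: the measured steps only compare methyl, hydrogen and trifluoromethyl at this carbon, and the two that end at compound 3 both show large losses when trifluoromethyl enters. The methoxycarbonyl group is new to the set, so direction is uncertain. The working expectation is a step of a 1.1-fold higher number from compound 3 to compound 4 (0.02 log units; within the scatter) in this assay, that is, no clear movement beyond the scatter. Compound 4 is estimated at 2000 nM in this assay, within a wide range from 400 nM to 10000 nM.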

Compound 4, half-maximal inhibitory concentration: 6200 nM
For compound 4 the middle estimate is 3.1-fold (0.49 log units) below the measured one; the range from low to high includes it.
By their numbers in this assay, from the lowest: compound 1; then compound 2; then compound 3; then compound 4.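

In this assay, methoxycarbonyl on this aromatic carbon next to the ring nitrogen gives a 3.3-fold higher number from compound 3 to compound 4 (0.51 log units; beyond the scatter), so compound 4 is the weakest of the set and a further loss is possible beyond that seen with trifluoromethyl. Among the compounds shown here, the same exchange gives a 45-fold higher number from compound 2 to compound 4 (1.65 log units; beyond the scatter) against hydrogen and a 160-fold higher number from compound 1 to compound 4 (2.19 log units; beyond the scatter) against methyl, which leaves methyl as the only one of the groups tried here to give a lower number than hydrogen. Trifluoromethyl and methoxycarbonyl carry the same count of heavy atoms, so that count alone does not set the number at this carbon. From the compounds shown here alone, whether an amine, a carboxylic acid or an ethyl chain on this carbon would fall nearer compound 1 or compound 4 remains open. No measurement shown here bears on the reason for this order.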